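Chloro in Place of Trifluoromethyl on a Weak Binder

This account rests on a few compounds, and the source may have more. Where it says the series, first, only, none or still open, it means among the compounds named here.

Compound 1 `CN(Cc1ccc2nccn2c1)c1nnc(-c2ccc(OC3CCCC3)cc2)o1` and compound 2 `CN(Cc1ccc2nccn2c1)c1nnc(-c2ccc(-c3ccccc3Cl)nc2)o1` are the two members of this set with a number in an assay on isolated protein for inhibition of tyrosine-protein kinase receptor TYRO3 (Homo sapiens), read by LC-MS, with stated times of 30 min and 180 min (on this read-out higher numbers stand for weaker inhibition and lower numbers for stronger inhibition), and compound 1 gives 79400 nM. Compound 2 gives 20000 nM. Compound 3 `CNC(=O)c1sc(N2CC3CC2(CNC(=O)c2c[nH]c4ncc(C(F)(F)F)cc24)C3)nc1C(F)(F)F` belongs to a different series. In this assay compound 3 reaches only a limit of the assay, > 100000 nM, so that it stands at the limit of > 100000 nM in this assay, at which 1 of the 3 values shown sits. Compound 4 `CNC(=O)c1sc(N2CC3CC2(CNC(=O)c2c[nH]c4ncc(Cl)cc24)C3)nc1C(F)(F)F` differs from compound 3 in one place: chloro in place of trifluoromethyl on an aromatic carbon. Among the measured compounds shown here, no measured step of this kind is available here. Compound 4 is expected to change little, the step that the limit leaves unreadable from compound 3 to compound 4 being estimated to remain within the scatter. The estimated value of compound 4 in this assay is 150000 nM, between 60000 nM and 400000 nM.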

Compound 4, half-maximal inhibitory concentration: 631 nM
The estimate for compound 4 lay 240-fold (2.38 log units) above the measured number, and the stated range ends above it.
By their numbers in this assay, from the lowest: compound 4; then compound 2; then compound 1. At a limit, above all of these: compound 3.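

In this assay, the group on this aromatic carbon proves decisive: chloro in place of trifluoromethyl gives an at least 150-fold lower number from compound 3 to compound 4 (2.19 log units; beyond the scatter). Among the compounds shown here, the earlier compounds offered no measured step of this kind, so this is the first reading of the change. The value of compound 3 is a limit of the assay, so the step gives only a minimum size: the limit of > 100000 nM in this assay, at which 1 of the 4 values shown sits.

The compounds shown leave open what a bromo, a methyl or a nitrile on this carbon would give. They also leave open whether the same change would act alike in another series.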